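From a hydroxymethyl to a longer sulfur-bearing chain

The compounds below may be only part of what the source reports. "The series", "measured", "known", "first", "only" and "open" are said of these compounds alone.

Compound 1 `C[C@@H](NCc1ccc(OCc2ccccc2)cc1)C(N)=O` gives 23.8 mg/kg
Compound 2 `CNC(=O)[C@H](C)NCc1ccc(OCc2ccccc2)cc1` gives 8.4 mg/kg
Compound 3 `CNC(=O)[C@H](CO)NCc1ccc(OCc2ccccc2)cc1` gives 15 mg/kg

In a functional assay on the whole organism with Mus musculus as the target (a higher number here means that more compound is needed for the effect, a lower number that less compound is needed), compound 3 gives 15 mg/kg and lies within the scatter of each of the other two compounds. Compound 4 `CNC(=O)[C@H](CCSC)NCc1ccc(OCc2ccccc2)cc1` carries (methylsulfanyl)methyl in place of hydroxy on a saturated chain carbon, two bonds along the chain from an amine nitrogen and a carbonyl carbon. The difference is (methylsulfanyl)methyl in place of hydroxy on a saturated chain carbon, two bonds along the chain from an amine nitrogen and a carbonyl carbon and it turns hydroxymethyl into 2-(methylsulfanyl)ethyl.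

Within the data shown here, the only measured change at this carbon is a 1.8-fold higher number from compound 2 to compound 3 (0.25 log units; within the scatter) and it placed hydroxy where hydrogen stood. A change elsewhere, 1-(methylcarbamoyl)ethyl in place of 1-carbamoylethyl, gave a 2.8-fold lower number from compound 1 to compound 2 (0.45 log units; beyond the scatter) as a modest step. Among the measured compounds shown here, no measured compound has sulfur in this chain, so the evidence is thin. For the measured compounds named here, with only that one step at this carbon as a guide, no step beyond the scatter is expected in this assay for this change. The estimated step is a 1.2-fold higher number from compound 3 to compound 4 (0.08 log units; within the scatter) for this swap. For compound 4 the estimated value is 18 mg/kg with an expected range from 7 mg/kg to 48 mg/kg around it.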

Compound 4, dose for half-maximal effect: 239 mg/kg
Compound 4: the middle estimate sits 13-fold (1.12 log units) below what was measured; measured number outside the range, above it.
By their numbers in this assay, from the lowest: compounds 2, 3 and 1 (each within the scatter of the next, the first and the last beyond it); then compound 4.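

Among these compounds, at this carbon, the earlier compounds showed only a small change: swapping hydrogen for hydroxy stayed within the scatter in this assay. The longer sulfur-bearing chain behaves very differently, with a 16-fold higher number from compound 3 to compound 4 (1.20 log units; beyond the scatter) and a 28-fold higher number from compound 2 to compound 4 (1.45 log units; beyond the scatter) in the same assay, so the large rise in the dose needed appears against both the hydroxymethyl and the methyl side chains. Nothing available here explains why this chain has such a large effect.

The compounds shown leave open whether the rise follows the sulfur atom or the length of the chain. A butyl chain, which has no sulfur, and a 2-hydroxyethyl chain, which keeps a hydroxy group on a longer chain, would help separate those two possibilities.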